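The source may hold more compounds than are shown below. What is called first, only, known or untested is meant among the compounds shown, and "the series" means these compounds.

Compound 1 `COc1ccccc1N1CCN(CCCNc2ccccc2C(=O)c2ccccc2)CC1`: 10 nM.
Compound 2 `CN(C)C(=O)c1cccnc1NCCCN1CCN(c2ccccc2OCC(F)(F)F)CC1`: 15.9 nM.

In a functional assay on aorta for antagonist activity at Alpha-1D adrenergic receptor (Rattus norvegicus) (a higher number here means weaker binding, a lower number tighter binding), compound 1 gives 10 nM, and compound 2 gives 15.9 nM; these two numbers lie within the usual scatter of each other, so nothing separates them. Compound 3 `CN(C)C(=O)c1cccnc1NCCCN1CCN(c2ccccc2C(F)(F)F)CC1` has not yet been measured. It differs from compound 2 in one place: trifluoromethyl in place of 2,2,2-trifluoroethoxy on an aromatic carbon. For the measured compounds named here, no measured pair shows this change, so its size is unknown; only a small step, in either direction or none beyond the scatter, is expected, a 1.3-fold higher number from compound 2 to compound 3 (0.10 log units; within the scatter). Compound 3 is therefore estimated at 20 nM, with a range from 8 nM to 50 nM.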

Compound 3, dissociation constant: 316 nM
Estimate against measurement, compound 3: 16-fold (1.20 log units) below; the whole stated range lies below it.
By their numbers in this assay, from the lowest: compounds 1 and 2 (each within the scatter of the next); then compound 3.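

In this assay the exchange of 2,2,2-trifluoroethoxy for trifluoromethyl on this aromatic carbon gives a 20-fold higher number from compound 2 to compound 3 (1.30 log units; beyond the scatter) and so shows that the read-out is highly sensitive to the group at this one place. Compounds 1 and 2 differ in more than one place and could not show this. Nothing measured here gives a reason for the step. On these data alone, it remains open whether the oxygen or the extra carbon of the departing group matters. A methoxy or an ethyl group on this carbon, in the core of compound 2, would separate the two.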